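Amide nitrogen substituent change from compound 2 to compound 3

The source may hold more compounds than are shown below. What is called first, only, known or untested is meant among the compounds shown, and "the series" means these compounds.

Measured compounds:
compound 1 `C=CC1=C(C(=O)NCc2ccc(Cl)cc2)C(c2ccc(OC)cc2)OC1`: in a functional assay on SW480 cells (Homo sapiens) for cytotoxicity, read by MTT assay, with a stated time of 24 h (a lower number here means a stronger inhibitor, a higher number a weaker inhibitor), compound 1 reaches only the limit > 100000 nM.
compound 2 `C=CC1=C(C(=O)NCC(C)C)C(c2ccc(OC)cc2)OC1`: in this assay compound 2 reaches only the limit > 100000 nM.

Compound 2 stands at the limit, as does compound 1 (the limit of > 100000 nM in this assay, at which 2 of the 2 values shown sit), so the step that the two limits leave unreadable from compound 1 to compound 2 cannot be read. Compound 3 `C=CC1=C(C(=O)Nc2ccccc2OC)C(c2ccc(OC)cc2)OC1` differs from compound 2 by 2-methoxyphenyl in place of isobutyl on an amide-type nitrogen. Going by the values given here, no measured step bears on this change, since both values shown are limits. Compound 3 is therefore expected to remain near the limit, with an estimated value of 100000 nM (30000 nM to 300000 nM). The expected step of a number no higher from compound 2 to compound 3 (the limit leaves the size open) is thus essentially none beyond the scatter.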

Compound 3, half-maximal inhibitory concentration: > 100000 nM
Compound 3 was reported as a limit (the forecaster's own chance of this, stated with the estimate: 80%); the middle value lies on the limit itself.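

The steps linking compound 1, compound 2 and compound 3 cannot be read, as all three stand at a limit: the limit of > 100000 nM in this assay, at which 3 of the 3 values shown sit. The compounds shown leave open how these amide nitrogen substituents rank in this assay.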